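Cytotoxicity of Quinoline Carbamates: From Methoxy to Methyl

The source may report more compounds than this note shows. Statements on the series, on what has been measured and on what is new or still open speak of the compounds shown alone.

Measured so far:
- compound 1 `COc1cc(NC(C)CCCN)c2nc(C(F)(F)F)cc(C)c2c1-c1cccc(C)c1`: 1.8 ug/mL
- compound 2 `COc1cc(NC(C)CCCNC(=O)OC(C)(C)C)c2nc(C(F)(F)F)cc(C)c2c1-c1cccc(C(F)(F)F)c1`: > 48 ug/mL
- compound 3 `COc1cccc(-c2c(OC)cc(NC(C)CCCNC(=O)OC(C)(C)C)c3nc(C(F)(F)F)cc(C)c23)c1`: > 80.2 ug/mL

In an ADME assay on RAW264.7 cells (Mus musculus) for cytotoxicity, read by MTT assay, with a stated time of 24 h (on this read-out higher numbers stand for weaker inhibition and lower numbers for stronger inhibition), compound 1 gives 1.8 ug/mL. Compound 2 reaches only the limit of the measurement, > 48 ug/mL. Compound 3 likewise reaches only a limit, > 80.2 ug/mL, so its position is known just as a boundary, as is that of one other value shown here. Among the measured compounds shown here, the single step with a shared backbone, a step that the two limits leave unreadable from compound 2 to compound 3, cannot be read for size because both ends are limits, which is what the limit of > 48 ug/mL in this assay, at which 1 of the 3 values shown sits, and the limit of > 80.2 ug/mL in this assay, at which 1 of the 3 values shown sits, state.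

Compound 4 `COc1cc(NC(C)CCCNC(=O)OC(C)(C)C)c2nc(C(F)(F)F)cc(C)c2c1-c1cccc(C)c1` is the compound still to be measured. It differs from compound 3 by methyl in place of methoxy on an aromatic carbon; in words, methyl in place of methoxy on an aromatic carbon, meta to a large group. For the measured compounds named here, no measured step covers this change. Both carbamate compounds sit at limits, so the step from compound 3 to compound 4 in this assay is expected to be small, and compound 4 is expected to land near 60 ug/mL, within 20 ug/mL to 120 ug/mL, most likely again reported as a limit, an expected step of an at least 1.3-fold lower number from compound 3 to compound 4 (0.12 log units; that floor lies within the scatter).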

Compound 4, half-maximal inhibitory concentration: > 48 ug/mL
Compound 4: a limit, no number; the forecaster's own chance of this, stated with the estimate: 65%; the middle value is on the limit's open side.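

With the 3-methylphenyl group now on the carbamate, compound 4 differs from compound 1 in one place only, and tert-butoxycarbonyl in place of hydrogen on the amine nitrogen gives an at least 26-fold higher number from compound 1 to compound 4 (1.42 log units; beyond the scatter) in this assay. Compound 4 gives > 48 ug/mL, which is a limit of the assay and not a number. The steps from compound 2 and compound 3 to compound 4 cannot be read, so nothing can be said about the size of either change at this position, meta to a large group: the limit of > 48 ug/mL in this assay, at which 2 of the 4 values shown sit.

On these data alone, it remains open whether methyl, methoxy and trifluoromethyl differ at all at this position, with the carbamate or with the free amine. As far as these compounds go, it is also open how an acetyl group on the amine nitrogen, a smaller group than tert-butoxycarbonyl, would read in this assay.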